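The compounds below may be only part of what the source reports. "The series", "measured", "known", "first", "only" and "open" are said of these compounds alone.

Measured so far in an ADME assay on MT4 cells (Homo sapiens) for cytotoxicity, read by MTT assay, with a stated time of 5 days; a lower number here means that less compound is tolerated, a higher number that more compound is tolerated:
Compound 1 `O=C1N(Cc2ccc(Cl)cc2Cl)c2cccn2S(=O)(=O)N1Cc1ccccc1` gives 218000 nM.
Compound 2 `C=CCN1C(=O)N(Cc2ccccc2)S(=O)(=O)n2cccc21` gives only a limit of the assay, > 802000 nM.
Compound 3 `O=C1N(Cc2ccccc2)c2cccn2S(=O)(=O)N1Cc1ccccc1` gives 196000 nM.

Compound 3 and compound 1 sit within the scatter of each other in this assay, as the step of a 1.1-fold lower number from compound 1 to compound 3 (0.05 log units; within the scatter) shows; the value of compound 2 is a limit and is not counted among the numbers (the limit of > 802000 nM in this assay, at which 1 of the 3 values shown sits).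

Compound 4 `O=C1N(Cc2ccccc2Cl)c2cccn2S(=O)(=O)N1Cc1ccccc1` carries the change (chloro in place of hydrogen on an aromatic carbon). The step that bears on it is a 1.1-fold lower number from compound 1 to compound 3 (0.05 log units; within the scatter), where removing both chloro groups from the benzyl left the number within the scatter. Adding back a single chloro is therefore expected to leave this assay essentially unchanged: the expected step is a 1.0-fold higher number from compound 3 to compound 4 (0.01 log units; within the scatter). For compound 4 the estimate is 200000 nM, with a range from 100000 nM to 400000 nM.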

Compound 4, half-maximal cytotoxic concentration: > 291000 nM
Compound 4: only a limit was reported; the forecaster's own chance of this, stated with the estimate: 10%; at least 1.4-fold (0.16 log units) between middle value and limit.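

Compound 4 gives only a limit in this assay: the limit of > 291000 nM in this assay, at which 1 of the 4 values shown sits.

With a single chloro, as 2-chlorophenyl, the series shows no drop in the number: an at least 1.4-fold higher number from compound 3 to compound 4 (0.17 log units; that floor lies within the scatter) and an at least 1.3-fold higher number from compound 1 to compound 4 (0.12 log units; that floor lies within the scatter) are floors only, so neither phenyl nor 2,4-dichlorophenyl can be ranked against 2-chlorophenyl. The step between compound 2 and compound 4 cannot be read, as both values are limits.

Still open, from the compounds shown here alone, are the actual number behind the limit of compound 4 and whether an amine or a carboxylic acid in place of chloro on that ring would move the number in this assay.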